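The source may report more compounds than this note shows. Statements on the series, on what has been measured and on what is new or still open speak of the compounds shown alone.

Measured compounds:
compound 1, `CCCCCCCCCCCc1nnc(NC(=O)Nc2c(C(C)C)cccc2C(C)C)s1`, 390 nM
compound 2, `CCCCCCCCCc1nnc(NC(=O)Nc2c(C(C)C)cccc2C(C)C)s1`, 150 nM
compound 3, `CCCCCCCCCCCCc1cc(NC(=O)Nc2c(C(C)C)cccc2C(C)C)on1`, 19 nM

The three compounds were tested in an assay on microsomes from intestine for inhibition of acyl-CoA:cholesterol acyltransferase (Oryctolagus cuniculus); a lower number here means a stronger inhibitor, a higher number a weaker inhibitor. Compound 1 and compound 2 share one core; the change between them is hydrogen in place of ethyl on a saturated chain carbon, nine bonds along the chain from an aromatic carbon, and in this assay it gave a 2.6-fold lower number from compound 1 to compound 2 (0.41 log units; beyond the scatter). Compound 3 carries a different core; the difference between the two cores is not broken down here. In this assay compound 3 gives the lowest number of the three, with compound 2 its nearest neighbour and compound 1 the furthest.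

Compound 4, `CCCCCCCCCCc1cc(NC(=O)Nc2c(C(C)C)cccc2C(C)C)on1`, has not yet been measured. It differs from compound 3 by hydrogen in place of ethyl on a saturated chain carbon, ten or more bonds along the chain from an aromatic carbon. This is the same kind of change as that from compound 1 to compound 2, but not the same: the place along the chain differs, as the two descriptions of the changes show, and the cores differ.

For compound 4 in this assay a step of about a 1.6-fold lower number from compound 3 to compound 4 (0.20 log units; within the scatter) is expected, resting on the earlier step of a 2.6-fold lower number from compound 1 to compound 2 (0.41 log units; beyond the scatter), with the caution that the core is different. The estimate for compound 4 is 12 nM, expected between 4 nM and 35 nM.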

Compound 4, half-maximal inhibitory concentration: 29 nM
Estimate against measurement, compound 4: 2.4-fold (0.38 log units) below, and the stated range covers the measured number.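

In this assay, hydrogen in place of ethyl on the chain of the core of compound 3 gave a 1.5-fold higher number from compound 3 to compound 4 (0.18 log units; within the scatter), a step that stays within the scatter, so on this core the change has no effect that can be told from repeat measurements. Set beside the earlier step, the same kind of change did not carry over from one core to the other: the same change on two cores in this assay, a 2.6-fold lower number (0.41 log units; beyond the scatter) from compound 1 to compound 2 and a 1.5-fold higher number (0.18 log units; within the scatter) from compound 3 to compound 4, 4.0-fold (0.60 log units) apart, beyond the scatter of two such steps. Going by these compounds alone, this shows that the size of the step on the core of compound 1 cannot be taken over as it stands to the core of compound 3, but it does not show why, since each core offers only one pair and the change sits at a different place along the chain in each.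

The compounds shown leave open how the number would run over a fuller set of chain lengths on either core, including a longer chain on the core of compound 3. They also leave open whether a chain carrying a carboxylic acid or an amine would follow either step.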